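A few compounds are considered here, and "the series" means these few. Any claim that something is new, unique, unknown or untested is made for them only; others in the source may bear on it.

Compound 1 `NC(=O)c1c(NC(=O)c2ccccc2Cl)sc2c1CCN(C(=O)Nc1ccccc1Cl)C2` and compound 2 `NC(=O)c1c(NC(=O)c2ccccc2F)sc2c1CCN(C(=S)Nc1ccccc1Cl)C2` share one core and were both tested in a functional assay on MKN-74 cells (Homo sapiens) for antiproliferative activity, with a stated time of 24 h; a lower number here means a stronger inhibitor, a higher number a weaker inhibitor. In this assay compound 1 gives 16300 nM. In this assay compound 2 gives 11100 nM, the lower of the two numbers, yet the gap to compound 1 lies within the scatter, so the two values show no difference that can be read as an order. Compound 3 `NC(=O)c1c(NC(=O)c2ccccc2F)sc2c1CCN(C(=O)Nc1ccccc1Cl)C2` is reached from compound 2 by a single change: a group of 10 heavy atoms (7 carbon, 1 nitrogen, 1 oxygen, 1 chlorine; one six-membered aromatic ring of carbon only) in place of a group of 10 heavy atoms (7 carbon, 1 nitrogen, 1 sulfur, 1 chlorine; one six-membered aromatic ring of carbon only), on an amine nitrogen in a ring. Going by the values given here, no measured pair in this set differs in that one place alone, so the size of that step cannot be read from the data. The change is therefore expected to be small, a 1.2-fold higher number from compound 2 to compound 3 (0.07 log units; within the scatter), in no direction beyond the scatter. For compound 3 the estimate in this assay is 13000 nM, with a range from 5500 nM to 31000 nM.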

Compound 3, half-maximal inhibitory concentration: 49600 nM
Estimate against measurement, compound 3: 3.8-fold (0.58 log units) below; measured number outside the range, above it.
By their numbers in this assay, from the lowest: compounds 2 and 1 (each within the scatter of the next); then compound 3.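

Both single changes now have a size in this assay, which the first two compounds could not give, since they differ in more than one place. On the amine nitrogen in a ring, (2-chlorophenyl)carbamoyl in place of its sulfur-containing counterpart gives a 4.5-fold higher number from compound 2 to compound 3 (0.65 log units; beyond the scatter), so exchanging sulfur for oxygen in this group is not a silent change in this series. On an aromatic carbon, fluoro in place of chloro gives a 3.0-fold higher number from compound 1 to compound 3 (0.48 log units; beyond the scatter), which makes compound 3 the weakest of the three and shows that this second place also affects the read-out. The compounds shown leave open how bromo or methyl would fall on that aromatic carbon, and whether the sulfur-to-oxygen step keeps its size with chloro there in place of fluoro. Nothing measured here accounts for either step.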